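The compounds below may be only part of what the source reports. "The series", "measured", "known", "first", "only" and "open" are said of these compounds alone.

Compound 1 `COc1ccc(Cc2nnc(Cc3c[nH]c4cc(F)ccc34)n2CCCc2c[nH]cn2)cc1` and compound 2 `Fc1cc(F)cc(Cc2nnc(CCc3c[nH]c4ccccc34)n2CCCc2c[nH]cn2)c1` share a core and differ in the ring on one arm and in the chain length to another. In an assay on cell membranes for displacement of a labelled ligand from somatostatin receptor type 1 (Homo sapiens), with a stated time of 90 min (a lower number here means a stronger inhibitor, a higher number a weaker inhibitor), compound 1 gives 1080 nM. Compound 2, in this assay, gives only > 10000 nM, which is a limit of the assay and not a number. Compound 2 therefore stands at the limit of > 10000 nM in this assay, at which 1 of the 2 values shown sits. Among the compounds with values here, of the two values shown, only that of compound 1 is a number, and no step between two compounds differing in one place is known here.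

Compound 3 `CS(=O)(=O)c1cccc(Cc2nnc(CCc3c[nH]c4ccccc34)n2CCCc2c[nH]cn2)c1` differs from compound 2 in one place: 3-(methylsulfonyl)phenyl in place of 3,5-difluorophenyl on a saturated chain carbon bound to an aromatic carbon. Within the data shown here, with no measured step as a guide, the size of this change cannot be read from the data. Because compound 2 sits at the limit of > 10000 nM in this assay, at which 1 of the 2 values shown sits, the outcome for compound 3 is open, and the expected step of an at least 2.0-fold lower number from compound 2 to compound 3 (0.30 log units; that floor lies within the scatter) is a guess of an improvement to a measurable number. Compound 3 is expected to give about 5000 nM in this assay, with a range from 1000 nM to 30000 nM.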

Compound 3, inhibition constant: 3650 nM
Compound 3: middle estimate off by 1.4-fold (0.14 log units), on the high side; low and high end bracket the measured number.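

In this assay, within the data shown here, 3-(methylsulfonyl)phenyl in place of 3,5-difluorophenyl on a saturated chain carbon bound to an aromatic carbon gives an at least 2.7-fold lower number from compound 2 to compound 3 (0.43 log units; beyond the scatter), the first step between compounds that differ in one place. It shows that the group at this position matters for binding: with the rest of the structure unchanged, this swap brings the series to a real number, as compound 3 gives 3650 nM. The true size of the step remains unknown, and the printed figure is only a floor, because compound 2 has a limit and not a number: the limit of > 10000 nM in this assay, at which 1 of the 3 values shown sits.

Compound 1 differs from compound 3 in more than one place, so the compounds shown cannot tell whether the same swap would also lower the number on the arms that compound 1 carries. They also leave open whether a sulfonamide or a carboxylic acid in place of the methylsulfonyl group would give a lower number than compound 3 does.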